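One Chain Added to Two Related Cores

The compounds below may be only part of what the source reports. "The series", "measured", "known", "first", "only" and "open" are said of these compounds alone.

Compound 1 `CC(C)=CCC/C(C)=C/C[C@]12C[C@@H](CC=C(C)C)C(C)(C)[C@](CC=C(C)C)(C(=O)CC1=O)C2=O` and compound 2 `CC(C)=CCC/C(C)=C/C[C@@H]1C[C@]2(CC=C(C)C)C(=O)[C@@](CC=C(C)C)(C(=O)C(C(=O)c3ccc(O)c(O)c3)=C2O)C1(C)C` share much of their framework, but the difference between the two cores is not broken down here. In a functional assay on HeLa cells (Homo sapiens) for inhibition (on this read-out lower numbers stand for stronger inhibition and higher numbers for weaker inhibition), compound 1 gives 6.64 ug/mL. For compound 2 this assay reports > 20 ug/mL, which is a limit of the assay and not a number. Compound 3 `CC(C)=CCC/C(C)=C/C[C@@H]1C[C@]2(C/C=C(\C)CCC=C(C)C)C(=O)[C@@](CC=C(C)C)(C(=O)C(C(=O)c3ccc(O)c(O)c3)=C2O)C1(C)C` differs from compound 2 by 3-methylbut-2-en-1-yl in place of hydrogen on a saturated chain carbon bound to a double-bonded chain carbon. In this assay compound 3 gives 8.09 ug/mL, so the change produced an at least 2.4-fold lower number from compound 2 to compound 3 (0.39 log units; beyond the scatter). Compound 1 and compound 3 lie within the usual scatter of each other.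

Compound 4 `CC(C)=CCC/C(C)=C/C[C@]12C[C@@H](CC=C(C)C)C(C)(C)[C@](C/C=C(\C)CCC=C(C)C)(C(=O)CC1=O)C2=O` has not been measured. It carries the same change, made on the core of compound 1: 3-methylbut-2-en-1-yl in place of hydrogen on a saturated chain carbon bound to a double-bonded chain carbon. Resting on an at least 2.4-fold lower number from compound 2 to compound 3 (0.39 log units; beyond the scatter), the step expected here is a 1.7-fold lower number from compound 1 to compound 4 (0.22 log units; within the scatter), kept modest since that earlier step is known only as a bound. In this assay compound 4 is therefore estimated at about 4 ug/mL, expected to fall between 1.5 ug/mL and 10 ug/mL.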

Compound 4, half-maximal inhibitory concentration: > 20 ug/mL
Compound 4 ended at the assay's limit (the forecaster's own chance of this, stated with the estimate: 5%); middle value at least 5.0-fold (0.69 log units) from the limit.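

In this assay, putting 3-methylbut-2-en-1-yl in place of hydrogen on the core of compound 1 produced an at least 3.0-fold higher number from compound 1 to compound 4 (0.47 log units; beyond the scatter) and so moved the number the opposite way from the same change on the core of compound 2. The change therefore does not carry over from one core to the other in this pair, and what it does here depends on the core that receives it: the same change on two cores in this assay, an at least 2.4-fold lower number (0.39 log units; beyond the scatter) from compound 2 to compound 3 and an at least 3.0-fold higher number (0.47 log units; beyond the scatter) from compound 1 to compound 4, at least 7.4-fold (0.87 log units) apart, beyond the scatter of two such steps. What this does not show is why the two cores part ways or how large either step truly is, because each step rests on a value that is a limit of the assay and not a number: the limit of > 20 ug/mL in this assay, at which 2 of the 4 values shown sit.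

The compounds shown leave open whether a longer chain, an amine or a carboxylic acid in the same place would also behave differently on the two cores. They also leave open how any further core would respond to this change.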